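Swapping the Ethynylphenyl Urea for an Acetamido-bromophenyl Urea

A few compounds are considered here, and "the series" means these few. Any claim that something is new, unique, unknown or untested is made for them only; others in the source may bear on it.

Of the compounds shown here, three sharing one core have been tested in a functional assay on MDA-MB-231 cells (Homo sapiens) for antiproliferative activity, read by MTT assay, with a stated time of 72 h; on this read-out higher numbers stand for weaker inhibition and lower numbers for stronger inhibition. Compound 1 `O=C(Nc1ccc(-c2noc(-c3cccc(NS(=O)(=O)c4ccccc4)c3)n2)c(Cl)c1)c1cccnc1` carries a phenylsulfonyl group on a nitrogen on an aromatic ring; in this assay compound 1 gives > 10000 nM, which is a limit of the assay and not a number. Compound 2 `O=C(Nc1cccc(-c2nc(-c3ccc(NC(=O)c4cccnc4)cc3Cl)no2)c1)Nc1cccc(C(F)(F)F)c1` instead bears a 3-(trifluoromethyl)phenyl urea, and compound 2 gives 1900 nM. Compound 3 `C#Cc1ccc(NC(=O)Nc2cccc(-c3nc(-c4ccc(NC(=O)c5cccnc5)cc4Cl)no3)c2)cc1` carries a 4-ethynylphenyl urea, and compound 3 gives > 10000 nM, again a limit of the assay. Because of the limit of > 10000 nM in this assay, at which 2 of the 3 values shown sit, the step that the two limits leave unreadable from compound 1 to compound 3 cannot be read, while the step of an at least 5.2-fold higher number from compound 2 to compound 3 (0.72 log units; beyond the scatter) shows that the aryl group on the urea matters.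

Compound 4 `CC(=O)Nc1ccc(NC(=O)Nc2cccc(-c3nc(-c4ccc(NC(=O)c5cccnc5)cc4Cl)no3)c2)cc1Br` differs from compound 3 in one place: 4-acetamido-3-bromophenyl in place of 4-ethynylphenyl on an amide-type nitrogen. Among the measured compounds shown here, the only step that bears on this is the one from compound 2 to compound 3, where a change of the urea aryl group moved the value beyond the scatter. For the measured compounds named here, since compound 3 sits at a limit, a return towards the number seen for compound 2 is plausible, but no measured pair shows this particular group. Compound 4 is therefore expected to show a step of an at least 2.0-fold lower number from compound 3 to compound 4 (0.30 log units; that floor lies within the scatter), giving an estimated 5000 nM, in the range from 1500 nM to 30000 nM.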

Compound 4, half-maximal inhibitory concentration: 1000 nM
For compound 4 the middle estimate is 5.0-fold (0.70 log units) above the measured one; measured number outside the range, below it.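

In this assay, the 4-acetamido-3-bromophenyl urea shows that replacing 4-ethynylphenyl on this amide-type nitrogen can restore a measurable value, with an at least 10-fold lower number from compound 3 to compound 4 (1.00 log units; beyond the scatter). Set against the 3-(trifluoromethyl)phenyl urea, the new group gives a 1.9-fold lower number from compound 2 to compound 4 (0.28 log units; within the scatter), so two differently substituted phenyl groups at this position give values that cannot be told apart, and the 4-ethynylphenyl urea is the one that stands out among the three ureas. Compound 3 sits at a limit of the assay and not at a number, so the first step gives only a floor and its true size cannot be read: the limit of > 10000 nM in this assay, at which 2 of the 4 values shown sit.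

Going by these compounds, it remains open whether the acetamido group, the bromine or the two together account for the step, and whether a simple 4-amino or 4-carboxylic acid group on the phenyl ring would behave like compound 4 or like compound 3. Also open, on these data alone, is whether the ethynyl group alone sets compound 3 apart, a question that an unsubstituted phenyl urea or a 4-ethylphenyl urea would address.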